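The source may hold more compounds than are shown below. What is called first, only, known or untested is meant among the compounds shown, and "the series" means these compounds.

Compound 1, `Cc1nc(C#Cc2cc(Br)cc([N+](=O)[O-])c2)cs1`, gives 0.93 nM in an assay on HEK293 cells for displacement of a labelled ligand from metabotropic glutamate receptor 5 (Rattus norvegicus), read by scintillation counting; a higher number here means a weaker inhibitor, a lower number a stronger inhibitor.
Compound 2, `Cc1nc(C#Cc2cc(Br)cc(C#N)c2)cs1`, gives 0.106 nM in this assay.
Compound 3, `Cc1nc(C#Cc2cc(F)cc(Br)c2)cs1`, gives 1.06 nM in this assay.

Compound 3 shows the highest number of the three. Its distance from compound 1 is small, a 1.1-fold higher number from compound 1 to compound 3 (0.06 log units; within the scatter), whereas compound 2 is the furthest away, a 10-fold higher number from compound 2 to compound 3 (1.00 log units; beyond the scatter). The step now taken is bromo in place of fluoro on an aromatic carbon, giving compound 4, `Cc1nc(C#Cc2cc(Br)cc(Br)c2)cs1`. Going by the values given here, no measured step swaps bromo for fluoro at this position, so the expectation rests on what has happened there so far: fluoro in place of nitro moved the number only within the scatter, a 1.1-fold higher number from compound 1 to compound 3 (0.06 log units; within the scatter), and only cyano in place of fluoro produced a step beyond it, a 10-fold higher number from compound 2 to compound 3 (1.00 log units; beyond the scatter). Two of the three groups tried here thus gave much the same number, and bromo, like fluoro, is a halogen. For compound 4 a step within the scatter is expected, a 1.3-fold lower number from compound 3 to compound 4 (0.12 log units; within the scatter). Compound 4 is therefore estimated at 0.8 nM in this assay, with a range from 0.25 nM to 2.5 nM.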

Compound 4, inhibition constant: 0.69 nM
Estimate against measurement, compound 4: 1.2-fold (0.06 log units) above; measured number inside the range.
By their numbers in this assay, from the lowest: compound 2; then compounds 4, 1 and 3 (each within the scatter of the next).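

In this assay, bromo in place of fluoro stays within the usual scatter (a 1.5-fold lower number from compound 3 to compound 4 (0.19 log units; within the scatter)), and so does bromo in place of nitro (a 1.3-fold lower number from compound 1 to compound 4 (0.13 log units; within the scatter)). A second halogen has now been tried at this position, and nitro, fluoro and bromo give numbers that cannot be told apart. Only the nitrile of compound 2 stands clear of the others, now also against bromo (a 6.5-fold higher number from compound 2 to compound 4 (0.81 log units; beyond the scatter)), so among these four compounds the one step-sized difference at this position belongs to the cyano group alone.

No measurement shown explains why compound 2 stands apart from the others. Going by these compounds, it remains open whether the cyano group is unique here or whether a methoxy group, an amine or a carboxylic acid at this position would also set a compound apart from the halogens.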